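The source may hold more compounds than are shown below. What is called first, only, known or untested is meant among the compounds shown, and "the series" means these compounds.

Compound 1 `COc1ccc(-n2cnc3cnc(-c4ccc(F)cc4C)cc32)cc1` gives 6 nM in a functional assay on HL-60 cells (Homo sapiens) for activation, read by flow cytometry, with a stated time of 4 days; a higher number here means that more compound is needed for the effect, a lower number that less compound is needed. Compound 2 `COc1ccc(-n2cnc3cnc(-c4ccc(F)cc4C)cc32)cc1F` gives 10 nM in this assay; with only these two numbers, compound 2 stands within the scatter of compound 1, the step of a 1.7-fold higher number from compound 1 to compound 2 (0.22 log units; within the scatter) being too small to separate them. Compound 3 `COc1ccc(-n2cnc3cnc(-c4ccc(F)cc4C)cc32)cc1C` carries the change (methyl in place of fluoro on an aromatic carbon). Among the compounds with values here, the one step that touches this place, a 1.7-fold higher number from compound 1 to compound 2 (0.22 log units; within the scatter), lay within the scatter, and a methyl there has no counterpart among the measured compounds, so in this assay the step is expected to be none beyond the scatter, estimated as a 1.2-fold higher number from compound 2 to compound 3 (0.08 log units; within the scatter). Compound 3 is therefore expected at 12 nM, with a range from 4 nM to 35 nM.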

Compound 3, half-maximal effective concentration: 14 nM
Compound 3: middle estimate off by 1.2-fold (0.07 log units), on the low side; measured number inside the range.
By their numbers in this assay, from the lowest: compounds 1, 2 and 3 (each within the scatter of the next, the first and the last beyond it).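

In this assay, within the data shown here, the position ortho to a methoxy group now shows a first modest step beyond the scatter, with methyl in place of hydrogen giving a 2.3-fold higher number from compound 1 to compound 3 (0.37 log units; beyond the scatter) at this place. Methyl in place of fluoro gives a 1.4-fold higher number from compound 2 to compound 3 (0.15 log units; within the scatter) and so does not separate these two groups here. Nothing available bears on the reason for these numbers. From the compounds shown here alone, whether an amine, a carboxylic acid or a longer chain at this place would give a larger step remains open. So does whether methyl in place of hydrogen gives a similar step elsewhere on the shared core.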